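The source may report more compounds than this note shows. Statements on the series, on what has been measured and on what is new or still open speak of the compounds shown alone.

Measured so far:
- compound 1 `CC(/C=N/Nc1ccc([N+](=O)[O-])cc1)=N\NC(=O)c1ccccc1`: in an ADME assay on J774 cells (Mus musculus, strain BALB/c) for cytotoxicity, read by resazurin assay, with a stated time of 72 h (on this read-out lower numbers stand for higher toxicity in this test and higher numbers for lower toxicity in this test), compound 1 reaches only the limit > 100000 nM
- compound 2 `CC(/C=N/Nc1ccc([N+](=O)[O-])cc1)=N\NC(=O)c1ccccc1Nc1ccccc1`: in this assay compound 2 likewise reaches only the limit > 100000 nM
- compound 3 `CC(/C=N/Nc1ccc([N+](=O)[O-])cc1)=N\NC(=O)c1ccccc1O`: in this assay compound 3 gives 29500 nM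

Going by the values given here, compound 3 stands as the only actual number among the three; the other two values are limits of the test, as the limit of > 100000 nM in this assay, at which 2 of the 3 values shown sit, shows. Compound 4 `CC(/C=N/Nc1ccc([N+](=O)[O-])cc1)=N\NC(=O)c1ccc(O)cc1` differs from compound 3 by 4-hydroxyphenyl in place of 2-hydroxyphenyl on a carbonyl carbon. Among the compounds with values here, no measured step compares the two placements of hydroxy. The steps that involve hydroxy at all are an at least 3.3-fold lower number from compound 1 to compound 3 (0.53 log units; beyond the scatter) and an at least 3.3-fold lower number from compound 2 to compound 3 (0.53 log units; beyond the scatter), and each sets hydroxy against a different group rather than against hydroxy moved to another position. The expectation for compound 4 is therefore loose: a step of a 1.7-fold higher number from compound 3 to compound 4 (0.23 log units; within the scatter) toward a higher number is expected, with a real chance that only a limit is reached. Compound 4 is estimated at 50000 nM, between 15000 nM and 150000 nM.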

Compound 4, half-maximal cytotoxic concentration: 51000 nM
Beside the measured number, compound 4's estimate is 1.0-fold (0.01 log units) below it; the measured number falls inside the stated range.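

In this assay, moving the hydroxy around the ring, with 4-hydroxyphenyl in place of 2-hydroxyphenyl on the carbonyl carbon, gives a 1.7-fold higher number from compound 3 to compound 4 (0.24 log units; within the scatter), so the two placements cannot be told apart here. Hydroxy in place of hydrogen gives an at least 1.9-fold lower number from compound 1 to compound 4 (0.29 log units; that floor lies within the scatter), so this pair alone does not show a real difference. That size is only a floor, since compound 1 sits at a limit of the test: the limit of > 100000 nM in this assay, at which 2 of the 4 values shown sit.

Open, going by these compounds, is whether 3-hydroxyphenyl would match these two placements. Also open, on these data alone, is whether a methoxy or an amine in place of the hydroxy would give a number or only the limit.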